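Working notes: 4-chlorophenyl to 4-methoxyphenyl

The source may hold more compounds than are shown below. What is called first, only, known or untested is meant among the compounds shown, and "the series" means these compounds.

In a functional assay on MCF7 cells (Homo sapiens) for inhibition, read by MTT assay, with a stated time of 48 h (a lower number here means a stronger inhibitor of growth, a higher number a weaker inhibitor of growth), compound 1 `Cn1cc(C2CC(c3ccccc3)=NN2C(=O)c2cccnc2Cl)c2ccccc21` gives > 10000 nM, which is a limit of the assay and not a number. Compound 2 `COc1ccc2c(c1)c(C1CC(c3ccc(F)cc3)=NN1C(=O)c1ccc(OC)nc1)cn2C` gives 480 nM. Compound 3 `COc1ccc2c(c1)c(C1CC(c3ccc(Cl)cc3)=NN1C(=O)c1ccc(OC)nc1)cn2C` gives 3710 nM, the higher of the two actual numbers. Compound 4 `COc1ccc(C2=NN(C(=O)c3ccc(OC)nc3)C(c3cn(C)c4ccc(OC)cc34)C2)cc1` carries methoxy in place of chloro on an aromatic carbon, para to a large group (methoxy in place of chloro on an aromatic carbon). For the measured compounds named here, one measured step bears on this place: a 7.7-fold higher number from compound 2 to compound 3 (0.89 log units; beyond the scatter), with chloro in place of fluoro, beyond the scatter. Going by the values given here, since compound 3 stands at 3710 nM, a move toward a lower number is expected, though no larger than that step. The expected step is a 2.5-fold lower number from compound 3 to compound 4 (0.39 log units; beyond the scatter). Compound 4 is estimated at 1500 nM, with an expected range of 350 nM to 6000 nM.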

Compound 4, concentration for 50% growth inhibition: 560 nM
Compound 4: the middle estimate sits 2.7-fold (0.43 log units) above what was measured, within the range that was stated.
By their numbers in this assay, from the lowest: compounds 2 and 4 (each within the scatter of the next); then compound 3. At a limit, above all of these: compound 1.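

At this position, on an aromatic carbon para to a large group, the chloro-to-methoxy change in this assay gives the first step away from chloro that does not involve fluoro (a 6.6-fold lower number from compound 3 to compound 4 (0.82 log units; beyond the scatter)). Methoxy in place of fluoro gives no separable change (a 1.2-fold higher number from compound 2 to compound 4 (0.07 log units; within the scatter)), so among the three groups shown, only chloro in compound 3 stands apart. No measurement shown accounts for either step. On these data alone, how an amine, a carboxylic acid or a longer chain such as ethoxy would fare at this position remains open.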